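The source may report more compounds than this note shows. Statements on the series, on what has been measured and on what is new or still open speak of the compounds shown alone.

Measured so far in a functional assay on L1210 cells (Mus musculus) for antiproliferative activity, read by cell counting, with a stated time of 2 days; a lower number here means a stronger inhibitor, a higher number a weaker inhibitor:
- Compound 1 `COc1cc(C(=O)c2sc(Nc3ccccc3)nc2N)cc(OC)c1OC`: 18 nM
- Compound 2 `COc1cc(C(=O)c2sc(Nc3ccc(F)cc3)nc2N)cc(OC)c1OC`: 900 nM
- Compound 3 `COc1cc(C(=O)c2sc(Nc3ccc(C)cc3)nc2N)cc(OC)c1OC`: 31 nM

Compound 3, at 31 nM, stands at the low end of these numbers together with compound 1: a 1.7-fold higher number from compound 1 to compound 3 (0.24 log units; within the scatter) lies within the scatter. Compound 2 is far off, and a 29-fold lower number from compound 2 to compound 3 (1.46 log units; beyond the scatter) is large.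

The next compound is compound 4 `COc1cc(C(=O)c2sc(Nc3ccc(Cl)cc3)nc2N)cc(OC)c1OC`, and the change is chloro in place of methyl on an aromatic carbon, para to a large group. For the measured compounds named here, no chloro compound has been measured yet, so the evidence is indirect. Three steps at this same place bear on it. Methyl in place of hydrogen gave a 1.7-fold higher number from compound 1 to compound 3 (0.24 log units; within the scatter), and fluoro in place of hydrogen gave a 50-fold higher number from compound 1 to compound 2 (1.70 log units; beyond the scatter). The closest parallel is methyl in place of fluoro, a 29-fold lower number from compound 2 to compound 3 (1.46 log units; beyond the scatter).

The only halogen so far, in compound 2 at 900 nM, points to a loss, but a single compound cannot show how far chloro will follow fluoro. In this assay a moderate move to a higher number is therefore expected, smaller than the large steps seen with compound 2. The estimated change is a 3.9-fold higher number from compound 3 to compound 4 (0.59 log units; beyond the scatter). Compound 4 is expected at 120 nM, with an estimated range of 25 nM to 700 nM.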

Compound 4, half-maximal inhibitory concentration: 420 nM
Compound 4: the middle estimate sits 3.5-fold (0.54 log units) below what was measured; measured number inside the range.
By their numbers in this assay, from the lowest: compounds 1 and 3 (each within the scatter of the next); then compound 4; then compound 2.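

In this assay, chloro at this place on the ring costs a great deal against both of the groups that are well accepted here, with a 23-fold higher number from compound 1 to compound 4 (1.37 log units; beyond the scatter) and with a 14-fold higher number from compound 3 to compound 4 (1.13 log units; beyond the scatter) on the methyl side. The loss seen earlier with a single halogen is therefore no longer tied to fluoro alone, although the two halogens do not coincide, as a 2.1-fold lower number from compound 2 to compound 4 (0.33 log units; beyond the scatter) is a modest step that still lies beyond the scatter. Among these four compounds, hydrogen and methyl thus stand apart from fluoro and chloro with no compound going against that split, and nothing measured here accounts for it.

The compounds shown leave open whether the split follows halogens as a class, which bromo or iodo in the same place would test, or whether other groups there, such as methoxy, ethyl or an amine, would stay with hydrogen and methyl. They also leave open whether chloro carries the same cost elsewhere on this phenyl ring, or whether it depends on the place para to a large group.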